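Exchanging one ring group in a low-solubility pair

The source may report more compounds than this note shows. Statements on the series, on what has been measured and on what is new or still open speak of the compounds shown alone.

Of the compounds shown here, two with a shared core have been tested in a physicochemical assay for solubility, with a stated time of 24 h, at pH 6.8; on this read-out higher numbers stand for higher solubility and lower numbers for lower solubility. Compound 1 `O=C(NC[C@@H]1[C@H]2CN(C(=O)OCc3cc(Cl)cc(Cl)c3)C[C@@H]12)c1ccc2[nH]c(=O)oc2c1` gives < 1 ug/mL, which is a limit of the assay and not a number. Among the compounds with values here, compound 2 `N#Cc1cc(COC(=O)N2C[C@@H]3[C@@H](CNC(=O)N4CCc5[nH]nnc5C4)[C@@H]3C2)cc(C(=O)OC(F)(F)F)c1` gives 5 ug/mL, the only true number so far, so its standing cannot yet be judged against another measured value. Compound 3 `N#Cc1cc(COC(=O)N2C[C@@H]3[C@@H](CNC(=O)N4CCc5c(O)noc5C4)[C@@H]3C2)cc(C(=O)OC(F)(F)F)c1` differs from compound 2 in one group on a carbonyl carbon: a group of 10 heavy atoms (6 carbon, 2 nitrogen, 2 oxygen; one five-membered aromatic ring with 2 hetero atoms, one six-membered non-aromatic ring with 1 hetero atom) in place of a group of 9 heavy atoms (5 carbon, 4 nitrogen; one five-membered aromatic ring with 3 hetero atoms, one six-membered non-aromatic ring with 1 hetero atom), on a carbonyl carbon. Within the data shown here, both groups hold a five-membered aromatic ring and a six-membered non-aromatic ring, but no measured step shows what such an exchange does. The expectation therefore starts from compound 2 at 5 ug/mL and allows only a small rise. The estimated step is a 1.6-fold higher number from compound 2 to compound 3 (0.20 log units; within the scatter). For compound 3 the expected value is 8 ug/mL, with an estimated range of 2 ug/mL to 30 ug/mL.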

Compound 3, solubility: > 113 ug/mL
Compound 3: a limit, no number; the forecaster's own chance of this, stated with the estimate: 10%; at least 14-fold (1.14 log units) between middle value and limit.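

In this assay, the place on a carbonyl carbon whose other neighbour is an amide-type nitrogen proves sensitive to the exchange, which comes with an at least 22-fold higher number from compound 2 to compound 3 (1.35 log units; beyond the scatter). The leaving and entering groups match in their ring types, their hydrogen-bond donor count and their lack of net charge, so a large step can accompany an exchange that leaves these counts unchanged; they differ in their heavy atoms and hydrogen-bond acceptor count. Compound 3 gives a limit of the assay and not a number: the limit of > 113 ug/mL in this assay, at which 1 of the 3 values shown sits.

This single step cannot show which difference between the two groups accounts for it, and the true value of compound 3 remains unknown. On these data alone, it is also open how the read-out would respond at this place to a simple amine or a carboxylic acid, or to the same exchange on a different core.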